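Hydroxyphenyl Swap Repeated on a Second Core

The compounds below may be only part of what the source reports. "The series", "measured", "known", "first", "only" and "open" are said of these compounds alone.

Compound 1 `O=C(O)Cn1c(=O)c(Oc2ccc(O)cc2)nc2cc(F)ccc21` and compound 2 `O=C(O)Cn1c(=O)c(Oc2cc(O)cc(O)c2)nc2cc(F)ccc21` share a core and differ in one group only, the change (3,5-dihydroxyphenyl in place of 4-hydroxyphenyl on an oxygen on an aromatic ring). In a physicochemical assay, read by spectrophotometry, with a stated time of 240 min, tested at 100 uM (on this read-out lower numbers stand for a weaker effect and higher numbers for a stronger effect at the one concentration tested), compound 1 gives 23.7%, and compound 2 gives 25.4%. The step of a number 1.7 percentage points higher from compound 1 to compound 2 (within the scatter) lies within the usual scatter, so the two numbers cannot be told apart.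

Compound 3 `O=C(O)Cn1c(=O)c(Oc2ccc(O)cc2)nc2ccc(Cl)cc21` carries the same 4-hydroxyphenyl on an oxygen on an aromatic ring as compound 1, but on another core; the difference between the two cores is not broken down here. In this assay compound 3 gives 84.8%, the highest of the three measured numbers, and its nearest neighbour, compound 2, lies a step beyond the scatter below it.

Compound 4 `O=C(O)Cn1c(=O)c(Oc2cc(O)cc(O)c2)nc2ccc(Cl)cc21` has not yet been measured. It arises from compound 3 through the change (3,5-dihydroxyphenyl in place of 4-hydroxyphenyl on an oxygen on an aromatic ring), the same change that turns compound 1 into compound 2: 3,5-dihydroxyphenyl in place of 4-hydroxyphenyl on an oxygen on an aromatic ring, with aromatic carbon as the other neighbour in both cases. Because the earlier step of a number 1.7 percentage points higher from compound 1 to compound 2 (within the scatter) stayed within the scatter, a similarly small step is expected here, a number 0.8 percentage points lower from compound 3 to compound 4 (within the scatter). Compound 4 is therefore estimated at about 84% in this assay, most likely between 68% and 96%. This rests on a single earlier pair measured on a different core, so the estimate remains loose.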

Compound 4, a percentage reported as activity, at one concentration (the size of the read-out at that concentration, not a potency): 91.3%
For compound 4 the middle estimate is 7.3 percentage points below the measured one, and the stated range covers the measured number.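

In this assay the swap of 4-hydroxyphenyl for 3,5-dihydroxyphenyl on the oxygen gives a number 6.5 percentage points higher from compound 3 to compound 4 (within the scatter) and on the other core the same swap gave a number 1.7 percentage points higher from compound 1 to compound 2 (within the scatter) so in both pairs the two numbers cannot be told apart, even though the entering group brings an extra hydroxyl. This shows that, for these two cores, the swap carried over from one core to the other without a step larger than the ordinary spread of repeated measurements, but two pairs are a small sample and say nothing about a third core, nor do they show that the two groups are equivalent in any other test. Nothing available here explains why the step stays this small on either core.

The compounds shown leave open how much the hydroxyl groups themselves contribute, since a plain phenyl, a methoxyphenyl or an aminophenyl on that same oxygen would each test this more directly than a swap between two hydroxyphenyl groups. They also leave open whether a swap of this kind would stay as small on a core carrying a different halogen or a methyl group.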